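The source may report more compounds than this note shows. Statements on the series, on what has been measured and on what is new or still open speak of the compounds shown alone.

Measured so far:
compound 1, `O=C(O)CC/C=C\CO[C@H]1C(OCc2ccc(-c3ccccc3)cc2)CC[C@@H]1N1CCCCCC1`: 25.1 nM
compound 2, `O=C(O)CC/C=C\CO[C@@H]1C(OCc2ccc(-c3ccccc3)cc2)CC[C@@H]1N1CCCCC1`: 15.9 nM
compound 3, `O=C(O)CC/C=C\CO[C@@H]1[C@@H](OCc2ccc(-c3ccccc3)cc2)CC[C@@H]1N1CCCCC1`: 1000 nM

In a functional assay for antagonist activity at thromboxane A2 receptor (Rattus norvegicus) (a higher number here means weaker binding, a lower number tighter binding), compound 1 stands second highest of the three; compound 2 sits within the scatter of it, while compound 3 lies far above both. Among the compounds with values here, the only single-place step measured is a 63-fold higher number from compound 2 to compound 3 (1.80 log units; beyond the scatter), which turns on a ring stereocentre drawn with a configuration in one compound and without one in the other (the fact that one of compounds 2 and 3 is drawn with a defined configuration and the other without, at the place where they differ). Compound 4, `CS(=O)(=O)Nc1ccccc1-c1ccc(COC2CC[C@H](N3CCCCCC3)[C@H]2OC/C=C\CCC(=O)O)cc1`, differs from compound 1 by methanesulfonamido in place of hydrogen on an aromatic carbon. Within the data shown here, no measured step touches that aromatic carbon, so no change beyond the scatter is expected: compound 4 is estimated at 20 nM, range 5 nM to 80 nM. That estimate means an expected 1.3-fold lower number from compound 1 to compound 4 (0.10 log units; within the scatter).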

Compound 4, dissociation constant: 3.98 nM
Estimate against measurement, compound 4: 5.0-fold (0.70 log units) above, and the stated range ends above it.
By their numbers in this assay, from the lowest: compound 4; then compounds 2 and 1 (each within the scatter of the next); then compound 3.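

Placing methanesulfonamido on this aromatic carbon, ortho to a large group, gives in this assay a 6.3-fold lower number from compound 1 to compound 4 (0.80 log units; beyond the scatter), so this position, which the earlier compounds left unchanged, responds to substitution. This is also the only step shown that lowers the number beyond the scatter. Nothing in the available evidence explains this step.

From the compounds shown here alone, whether a carboxylic acid, an amine or acetamido on the same carbon would do the same remains open. So does whether the step would carry over to the core of compound 2.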